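The source may report more compounds than this note shows. Statements on the series, on what has been measured and on what is new or still open speak of the compounds shown alone.

In a functional assay on H22 cells (Mus musculus) for inhibition, read by MTT assay, with a stated time of 24 h (on this read-out lower numbers stand for stronger inhibition and higher numbers for weaker inhibition), compound 1 `FC(F)(F)c1cc(NC[C@H]2CCCN2)c2cn[nH]c2c1` gives 19700 nM. Compound 2 `COc1cc(CNc2cc(Br)cc3[nH]ncc23)c([N+](=O)[O-])cc1OC` gives 6110 nM, a lower number by more than the usual scatter, so compound 1 has the higher of the two exact numbers and the weaker inhibition. Compound 3 `O=[N+](O)c1c(Cl)cccc1CNc1cc(C(F)(F)F)cc2[nH]ncc12` reads > 20000 nM, which is a limit of the assay and not a number.

Compound 4 `FC(F)(F)c1cc(NC[C@@H]2CCCCN2)c2cn[nH]c2c1` has piperidin-2-yl in place of pyrrolidin-2-yl on a saturated chain carbon bound to a nitrogen on an aromatic ring. Going by the values given here, no two measured compounds here differ in one place only, so the data offer no direct guide to this change. The expectation is therefore no shift beyond the scatter in either direction, leaving compound 4 a weak inhibitor close to compound 1 at 19700 nM. The estimated change is small, as a 1.3-fold lower number from compound 1 to compound 4 (0.12 log units; within the scatter) shows. A reading that is only a limit is also possible. For compound 4, the expected value is 15000 nM, with an estimated range of 6000 nM to 30000 nM.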

Compound 4, half-maximal inhibitory concentration: 21700 nM
Estimate against measurement, compound 4: 1.4-fold (0.16 log units) below; measured number inside the range.
By their numbers in this assay, from the lowest: compound 2; then compounds 1 and 4 (each within the scatter of the next).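

In this assay, going by these compounds alone, the step from pyrrolidin-2-yl to piperidin-2-yl on a saturated chain carbon bound to a nitrogen on an aromatic ring gives a 1.1-fold higher number from compound 1 to compound 4 (0.04 log units; within the scatter), the only direct comparison of one change in this set. On this core and at this place, swapping the five-membered ring for the six-membered ring therefore leaves the read-out unchanged within the scatter, although the step says nothing about the other groups that could stand here. Compound 3 reads only as a limit of the assay and not as a number, so it cannot be placed in the order: the limit of > 20000 nM in this assay, at which 1 of the 4 values shown sits.

Still open, from the compounds shown here alone, is whether a larger ring such as azepan-2-yl, or an open-chain amine at the same place, would move the number beyond the scatter. Also open, going by these compounds, is whether the same ring swap stays this flat when the trifluoromethyl group on the core is replaced by another group.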